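Varying the aryl group on the ring amine: compounds 1 to 4

The source may hold more compounds than are shown below. What is called first, only, known or untested is meant among the compounds shown, and "the series" means these compounds.

Compound 1 `COc1cc2ncnc(Nc3cccc(F)c3)c2cc1OCCCCC(=O)Nc1ccc(S(N)(=O)=O)cc1`, compound 2 `COc1cc2ncnc(Nc3ccc(F)cc3)c2cc1OCCCCC(=O)Nc1ccc(S(N)(=O)=O)cc1` and compound 3 `COc1ccc(Nc2ncnc3cc(OC)c(OCCCCC(=O)Nc4ccc(S(N)(=O)=O)cc4)cc23)cc1` share one core and differ only in the aryl group carried on the amine nitrogen. In a functional assay on A549 cells (Homo sapiens) for antiproliferative activity, read by MTT assay, with a stated time of 72 h (a lower number here means a stronger inhibitor, a higher number a weaker inhibitor), compound 1 gives only a limit, > 40000 nM. Compound 2 likewise gives only a limit in this assay, > 40000 nM. Compound 3 stands at the same limit in this assay, > 40000 nM. Accordingly the steps a step that the two limits leave unreadable from compound 1 to compound 2, a step that the two limits leave unreadable from compound 1 to compound 3 and a step that the two limits leave unreadable from compound 2 to compound 3 cannot be read in size or direction, since all three values sit at the limit of > 40000 nM in this assay, at which 3 of the 3 values shown sit.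

Compound 4 `COc1cc2ncnc(Nc3ccc(F)c(Br)c3)c2cc1OCCCCC(=O)Nc1ccc(S(N)(=O)=O)cc1` is the next member: 3-bromo-4-fluorophenyl in place of 4-methoxyphenyl on a nitrogen on an aromatic ring. The three measured steps all alter the same aryl group and so all bear on this change, yet none yields a readable size, so nothing in the series distinguishes one aryl group from another. Compound 4 is therefore expected to remain at the limit in this assay, the step of a number no higher from compound 3 to compound 4 (the limit leaves the size open) being expected to show no change beyond scatter. Compound 4 is estimated at 40000 nM, between 10000 nM and 80000 nM, and most likely to be reported again only as a limit.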

Compound 4, half-maximal inhibitory concentration: 16000 nM
Beside the measured number, compound 4's estimate is 2.5-fold (0.40 log units) above it, within the range that was stated.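

The aryl group on the amine nitrogen can move a compound off the limit in this assay: 3-bromo-4-fluorophenyl in place of 4-methoxyphenyl gives an at least 2.5-fold lower number from compound 3 to compound 4 (0.39 log units; beyond the scatter). Bromo in place of hydrogen on an aromatic carbon, the only one-atom change among these steps, gives an at least 2.5-fold lower number from compound 2 to compound 4 (0.39 log units; beyond the scatter), and 3-bromo-4-fluorophenyl in place of 3-fluorophenyl gives an at least 2.5-fold lower number from compound 1 to compound 4 (0.39 log units; beyond the scatter). Compound 1, compound 2 and compound 3 remain limits and not numbers: the limit of > 40000 nM in this assay, at which 3 of the 4 values shown sit.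

On these data alone, the steps among compound 1, compound 2 and compound 3 cannot be read, and the full size of each new step stays open. Also open, as far as these compounds go, is whether chloro or ethynyl in place of bromo, or a shorter chain on the shared core, would shift the value in this assay further.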